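A hydroxy group lost from compound 3

The compounds below may be only part of what the source reports. "The series", "measured", "known", "first", "only" and "open" are said of these compounds alone.

Compound 1 `Cc1cc(/C=C/c2ccc(O)cc2)[nH]n1` gives 48100 nM 
Compound 2 `COc1cc(/C=C/c2cc(C)[nH]n2)ccc1O` gives 16500 nM 
Compound 3 `Cc1cc(/C=C/c2ccc(O)c(O)c2)on1` gives 6300 nM 

These values come from a functional assay on MCF7 cells (Homo sapiens) for cytotoxicity, read by MTT assay, with a stated time of 72 h (a lower number here means a stronger inhibitor, a higher number a weaker inhibitor), and compound 3 holds the lowest number of the three. Its gaps to compound 2 and to compound 1 both lie beyond the scatter of repeated measurements.

Compound 4 `Cc1cc(/C=C/c2ccc(O)cc2)on1` has not yet been measured and differs from compound 3 in one place. The change is hydrogen in place of hydroxy on an aromatic carbon and it puts hydrogen in place of hydroxy on an aromatic carbon, ortho to a hydroxy group.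

Within the data shown here, no measured pair shows this change alone, so the evidence for its size is indirect. Compound 3 at 6300 nM is the only one of the three that carries this hydroxy group. Compound 2 at 16500 nM and compound 1 at 48100 nM lack it, but they also differ from compound 3 elsewhere. A higher number in this assay is therefore expected, which would mean a weaker inhibitor. The estimated move is a 4.0-fold higher number from compound 3 to compound 4 (0.60 log units; beyond the scatter) and it would lie beyond the scatter. For compound 4 the estimated value is 25000 nM with an expected range from 10000 nM to 65000 nM in this measurement.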

Compound 4, half-maximal inhibitory concentration: 50200 nM
For compound 4 the middle estimate is 2.0-fold (0.30 log units) below the measured one; measured number inside the range.
By their numbers in this assay, from the lowest: compound 3; then compound 2; then compounds 1 and 4 (each within the scatter of the next).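

Among these compounds, the step isolates this position for the first time: with everything else in the molecule held constant, putting hydrogen in place of the hydroxy group ortho to a hydroxy group gives an 8.0-fold higher number from compound 3 to compound 4 (0.90 log units; beyond the scatter) in this assay. Among the compounds shown here, the earlier compounds lacked this hydroxy group but also differed from compound 3 elsewhere, so only this pair ties a change in the number to this one replacement, and the step shows that the remaining hydroxy group alone does not preserve the value of compound 3. The data give no measured property that would explain the size of this step.

The compounds shown leave open what an amine or a fluorine atom at this position would give, so they cannot tell whether the hydroxy group itself is needed or whether another group could take its place. For the compounds shown here, it also remains open whether the same replacement would produce a step of similar size on the core of compound 1, where no pair shows this change.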